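A few compounds are considered here, and "the series" means these few. Any claim that something is new, unique, unknown or untested is made for them only; others in the source may bear on it.

Three compounds carry a measured number in a physicochemical assay for lipophilicity; a lower number here means a more polar compound, a higher number a more lipophilic compound. Compound 1 `CCOC(=O)/C=C(C)/C=C/CC(C)CCC(O)C(C)C` gives 4.65. Compound 2 `CCOC(=O)/C=C(C)/C=C/CC(C)CCC(OC)C(C)C` gives 5.54. Compound 3 `COC(CCC(C)C/C=C/C(C)=C/C(=O)OC(C)C)C(C)(C)OC` gives 4.75. Compound 4 `COC(C)(C)C(O)CCC(C)C/C=C/C(C)=C/C(=O)OC(C)C` has not yet been measured. The difference between the core of compound 2 and the core of compound 3 is not broken down here; compound 3 and compound 1 sit within the usual scatter of each other, while compound 2 stands beyond it from both. Between compound 2 and compound 1 the change is hydrogen in place of methyl on an oxygen on a saturated carbon and the step was a number 0.89 log units lower from compound 2 to compound 1 (beyond the scatter). Between compound 3 and compound 4 the change is hydrogen in place of methyl on an oxygen on a saturated carbon, the same change at the same place, and no other pair among the compounds shown carries this change. Compound 4 is therefore expected to move by a number 0.85 log units lower from compound 3 to compound 4 (beyond the scatter), close to the earlier step, because a number 0.89 log units lower from compound 2 to compound 1 (beyond the scatter) is the one measured instance of this change and nothing shown argues for a different size. Compound 4 is estimated at 3.9, most likely between 3.4 and 4.5 in this assay.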

Compound 4, partition coefficient: 3.86
The estimate for compound 4 lay 0.04 log units above the measured number; the range from low to high includes it.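

In this assay, hydrogen in place of methyl on an oxygen on a saturated carbon gave a number 0.89 log units lower from compound 3 to compound 4 (beyond the scatter), and the same change on the other core had given a number 0.89 log units lower from compound 2 to compound 1 (beyond the scatter), so the printed size of the step is the same on both cores. This rests on just two matched pairs, and it shows that the change carried from one core to the other in this series, not that it would carry to any further core. Nothing measured here explains why the step kept its size.

The compounds shown cover only methoxy to hydroxy, so they leave open whether an amine or a carboxylic acid in place of the hydroxy, or ethoxy in place of the methoxy, would give a step of similar size. They also leave open how the same change would read on a core with a longer chain.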